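Removing the Fluoro Group on a Shared Core

The source may report more compounds than this note shows. Statements on the series, on what has been measured and on what is new or still open speak of the compounds shown alone.

Compound 2 `O=C(N/N=C/c1ccc(F)cc1)Nc1ccc(Oc2ccnc3[nH]ccc23)cc1` and compound 1 `O=C(N/N=C/c1ccccc1)Nc1ccc(Oc2ccnc3[nH]ccc23)cc1` share one core and differ only by hydrogen in place of fluoro on an aromatic carbon. In a functional assay on A549 cells (Homo sapiens) for antiproliferative activity, read by MTT assay, with a stated time of 72 h (a lower number here means a stronger inhibitor, a higher number a weaker inhibitor), compound 2 gives 1430 nM, whereas compound 1 gives 17200 nM; the step is a 12-fold higher number from compound 2 to compound 1 (1.08 log units; beyond the scatter). Compound 3 `CN(C)CCn1cccc1/C=N/NC(=O)Nc1ccc(Oc2ccnc3[nH]ccc23)c(F)c1` carries a different arm on the same core; the difference between the two cores is not broken down here. In this assay compound 3 is reported as "not active" (no number reported), and no number is given for it. Compound 4 `CN(C)CCn1cccc1/C=N/NC(=O)Nc1ccc(Oc2ccnc3[nH]ccc23)cc1` is the counterpart of compound 3 with hydrogen in place of fluoro on an aromatic carbon. The surroundings of the place differ from the first pair: there the position is para to a large group, here it is ortho to a large group and meta to a large group, so this is the same kind of change, not the same. The earlier step of a 12-fold higher number from compound 2 to compound 1 (1.08 log units; beyond the scatter) went toward weaker inhibition when fluoro left, and compound 3 already shows no activity in this assay. Compound 4 is therefore expected to be a weak inhibitor, estimated at 40000 nM, between 10000 nM and 150000 nM, with a real chance that only a limit is reported.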

Compound 4, half-maximal inhibitory concentration: "not active" (no number reported)
No number was reported for compound 4, and the estimate cannot be compared.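

In this assay compound 3 and compound 4 are both reported as "not active" without a number, so no step can be read between them. No supporting data bear on this result. The compounds shown leave open whether exchanging fluoro for hydrogen changes activity at all on the arm that compound 3 and compound 4 share.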